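Cytotoxicity in liver cells across a small amide series

This account rests on a few compounds, and the source may have more. Where it says the series, first, only, none or still open, it means among the compounds named here.

Measured compounds:
compound 1, `COc1cccc(NC(=O)c2c(NO)cc(-c3ccccc3)oc2=O)c1`, > 20000 nM
compound 2, `CCOc1ccccc1NC(=O)c1c(NO)cc(-c2ccccc2)oc1=O`, > 20000 nM
compound 3, `COc1cccc(NC(=O)c2c(NCCO)cc(-c3cccs3)oc2=O)c1`, > 20000 nM

The three measured compounds were run in an ADME assay on Huh-7 cells (Homo sapiens) for cytotoxicity, with a stated time of 3 days; a higher number here means that more compound is tolerated, a lower number that less compound is tolerated. Compound 1 gives > 20000 nM, which is a limit of the assay and not a number. Compound 2 likewise gives > 20000 nM, again a limit rather than a number. Compound 3 also reaches only a limit, > 20000 nM.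

Compound 1 and compound 2 differ in one place: 2-ethoxyphenyl in place of 3-methoxyphenyl on an amide-type nitrogen. The step that the two limits leave unreadable from compound 1 to compound 2 cannot be sized, since both values sit at the limit of > 20000 nM in this assay, at which 3 of the 3 values shown sit. Compound 3 carries a different core from compound 1; the difference between the two cores is not broken down here.

The unmeasured compound 4, `CCOc1ccccc1NC(=O)c1c(NCCO)cc(-c2cccs2)oc1=O`, stands to compound 3 as compound 2 stands to compound 1, with the same change in the same place: 2-ethoxyphenyl in place of 3-methoxyphenyl on an amide-type nitrogen. Because all three measured values sit at the limit of > 20000 nM in this assay, at which 3 of the 3 values shown sit, the change from compound 1 to compound 2 shows no movement that could be read, and the same change on the core of compound 3 offers nothing to push compound 4 away from that limit. Compound 4 is therefore expected to sit at the limit as well, and the step of a number no higher from compound 3 to compound 4 (the limit leaves the size open) is expected to be flat. The estimate for compound 4 in this assay is 20000 nM, with a range from 10000 nM to 40000 nM.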

Compound 4, half-maximal cytotoxic concentration: 10000 nM
Compound 4: middle estimate off by 2.0-fold (0.30 log units), on the high side, within the range that was stated.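

In this assay, placing 2-ethoxyphenyl in place of 3-methoxyphenyl on an amide-type nitrogen gives an at least 2.0-fold lower number from compound 3 to compound 4 (0.30 log units; that floor lies within the scatter), so compound 4 is the only compound shown with a measured number rather than an assay limit. The same change on the core of compound 1 cannot be sized, because both of its values are limits, as are those of the other compound at that limit: the limit of > 20000 nM in this assay, at which 3 of the 4 values shown sit. The result therefore shows that the change can be carried to the core of compound 3 and still leave a readable value, but the floor of the step lies within the usual scatter, and it does not show that the change has a real effect on either core or that its effect differs between them.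

The compounds shown leave open whether the readable value of compound 4 depends on the ethoxy group itself, for instance whether a longer chain such as butoxy, an amine such as dimethylamino, or a carboxylic acid at that place would give a number in this assay. It also remains open which part of the difference between the two cores goes with the readable value, since no pair shown separates those parts.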